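Phenyl for methyl on the ring nitrogen of compound 2

The source may report more compounds than this note shows. Statements on the series, on what has been measured and on what is new or still open speak of the compounds shown alone.

Measured compounds in a functional assay on CHO cells for agonist activity at Melanocyte-stimulating hormone receptor (Homo sapiens), read by a luciferase reporter, with a stated time of 4 h; on this read-out lower numbers stand for an effect already at smaller amounts and higher numbers for an effect only at larger amounts of compound:
compound 1, `CCn1nc(CC2(OC)C(=O)N(CC(=O)N(c3ccc(OC)cc3)C(C)C)C=CN(c3ccccc3)C2=O)c2ccccc21`: 31600 nM; > 30000 nM (2 entries)
compound 2, `CC(C)N(C(=O)CN1C=CN(C)C(=O)C(Cc2n[nH]c3cc(F)ccc23)C1=O)c1ccc(F)cc1`: 3720 nM
compound 3, `CC(C)N(C(=O)CN1C=CN(c2ccccc2)C(=O)C(Cc2n[nH]c3ccccc23)C1=O)c1ccccc1`: 708 nM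

Compound 1 appears twice in this assay, (the several entries of compound 1 in this assay, 31600 nM; > 30000 nM (2 entries)). One of the two entries of compound 1 is a limit of the assay and not a number.

Among the compounds with a single number, compound 2 stands highest. Its nearest neighbour is compound 3, whose number is lower by a gap beyond the usual scatter. Compound 3 differs from compound 2 in more than one place, so the two values are compared only as they stand.

Compound 4, `CC(C)N(C(=O)CN1C=CN(c2ccccc2)C(=O)C(Cc2n[nH]c3cc(F)ccc23)C1=O)c1ccc(F)cc1`, is not yet measured. It differs from compound 2 in one place: phenyl in place of methyl on an amide-type nitrogen in a ring. The fluorine substituents of compound 2 are kept, while the ring nitrogen now carries the same phenyl as compound 3.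

Within the data shown here, no measured pair shows this change alone. Given that compound 3, which bears the phenyl, gives 708 nM, compound 4 is expected to move toward that value rather than stay at the level of compound 2. The expected step is a 3.7-fold lower number from compound 2 to compound 4 (0.57 log units; beyond the scatter). For compound 4 the estimate in this assay is 1000 nM, with a range from 300 nM to 3500 nM.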

Compound 4, half-maximal effective concentration: 14.1 nM
The estimate for compound 4 lay 71-fold (1.85 log units) above the measured number; the measured number lies below the stated range.
By their numbers in this assay, from the lowest: compound 4; then compound 3; then compound 2.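

In this assay the amide-type nitrogen of the seven-membered non-aromatic ring emerges as a position with a strong hold on the read-out: phenyl in place of methyl there gives a 260-fold lower number from compound 2 to compound 4 (2.42 log units; beyond the scatter) with the fluorine substituents kept as they were. Among these compounds, the earlier compounds could not show this, since the only comparison among compounds with single numbers involved a difference in more than one place, and this step is the first reading of this nitrogen on its own. At this position, in this pair, the single carbon of methyl is the far poorer choice, and the six-carbon aromatic ring is not merely accepted but goes with a large change in the favourable direction.

On these data alone, what the two fluorine substituents contribute stays open, as does whether benzyl or cyclohexyl on this ring nitrogen would follow phenyl or fall back toward methyl. The one available supporting observation concerns only the repeated entries of compound 1, and nothing on hand bears on why this step is so large.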